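The compounds below may be only part of what the source reports. "The series", "measured", "known", "first", "only" and "open" are said of these compounds alone.

Measured so far in a functional assay on the whole organism with Rattus norvegicus as the target; on this read-out lower numbers stand for an effect already at smaller amounts and higher numbers for an effect only at larger amounts of compound:
- Compound 1 `CCCNc1cccc(NC(=O)C(=O)OCC)c1C#N`: 0.5 mg/kg
- Compound 2 `CCCCNc1cccc(NC(=O)C(=O)OCC)c1C#N`: 0.3 mg/kg
- Compound 3 `CCOC(=O)C(=O)Nc1cccc(N(CC)CC)c1C#N`: 0.7 mg/kg

Compound 1 lies within the scatter of the other two, as shown by a 1.7-fold lower number from compound 1 to compound 2 (0.22 log units; within the scatter) and a 1.4-fold higher number from compound 1 to compound 3 (0.15 log units; within the scatter). Only a 2.3-fold higher number from compound 2 to compound 3 (0.37 log units; beyond the scatter) goes beyond the scatter, and modestly so.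

Compound 4 `CCOC(=O)C(=O)Nc1cccc([N+](=O)[O-])c1C#N` keeps the core of compound 1 but has nitro in place of propylamino on an aromatic carbon, ortho to a cyano group: nitro in place of propylamino on an aromatic carbon. The closest evidence comes from the two swaps at that same carbon, a 1.4-fold higher number from compound 1 to compound 3 (0.15 log units; within the scatter) and a 2.3-fold higher number from compound 2 to compound 3 (0.37 log units; beyond the scatter). Among the measured compounds shown here, both exchange one amino group for another, and no measured step removes the amino nitrogen there. These small steps therefore set only a loose guide, and the size of this larger change is poorly fixed. A move towards a higher number in this assay is expected, greater than the measured steps. The expected change is a 3.0-fold higher number from compound 1 to compound 4 (0.48 log units; beyond the scatter). Compound 4 is estimated at 1.5 mg/kg, with an expected range from 0.3 mg/kg to 8 mg/kg.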

Compound 4, dose for half-maximal effect: 0.4 mg/kg
Compound 4: middle estimate off by 3.8-fold (0.57 log units), on the high side, and the stated range covers the measured number.
By their numbers in this assay, from the lowest: compounds 2, 4, 1 and 3 (each within the scatter of the next, the first and the last beyond it).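

In this assay, nitro on the aromatic carbon ortho to a cyano group takes the place of each of the three amino groups without any step going beyond the scatter (a 1.3-fold lower number from compound 1 to compound 4 (0.10 log units; within the scatter); a 1.8-fold lower number from compound 3 to compound 4 (0.24 log units; within the scatter); a 1.3-fold higher number from compound 2 to compound 4 (0.12 log units; within the scatter)). The earlier steps shown here only exchanged one amino group for another, whereas these show that the amino nitrogen at this carbon can be lost while the number stays within the range set by the amino compounds. Nothing available explains why this exchange leaves the number so little changed.

From the compounds shown here alone, it remains open whether this tolerance extends to a carboxylic acid, a methoxy group, a piperidine ring or plain hydrogen on this carbon. Going by these compounds, it is also open whether nitro would behave the same way if the nitrile were replaced by a chlorine atom.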